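Urea to amide at the carbonyl of compound 3

The compounds below may be only part of what the source reports. "The series", "measured", "known", "first", "only" and "open" are said of these compounds alone.

Compound 3, `O=C(N1CCC(F)CC1)N1CC(c2nc(-c3cccc(Cl)c3)no2)C1`, has been tested in an assay on HEK293 cells for negative allosteric modulation of metabotropic glutamate receptor 5 (Homo sapiens), read by FLIPR; a lower number here means a stronger inhibitor, a higher number a weaker inhibitor. In this assay compound 3 gives > 10000 nM, which is a limit of the assay and not a number. Two related compounds show the same picture. Compound 1, `O=C(c1ccc(Cl)cc1)N1CC(c2nc(-c3cccc(F)c3)no2)C1`, gives in this assay > 10000 nM, again only a limit. Compound 2, `O=C(C1CCCCC1)N1CC(c2nc(-c3cccc(F)c3)no2)C1`, gives in this assay > 10000 nM, also a limit. For the measured compounds named here, the one single change between measured compounds, a step that the two limits leave unreadable from compound 1 to compound 2, therefore cannot be read, and the whole set rests on (the limit of > 10000 nM in this assay, at which 3 of the 3 values shown sit).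

Compound 4, `O=C(C1CCC(F)(F)CC1)N1CC(c2nc(-c3cccc(Cl)c3)no2)C1`, differs from compound 3 by 4,4-difluorocyclohexyl in place of 4-fluoropiperidin-1-yl on a carbonyl carbon. The change from compound 1 to compound 2 also sits on the carbonyl carbon of the shared core, yet its size is hidden by the two limits, so it gives no direction for the new step. With every measured value sitting at the limit, the account expects compound 4 to stay where compound 3 stands, and the step that the limit leaves unreadable from compound 3 to compound 4 is expected to be none beyond the scatter. The estimate for compound 4 in this assay is 15000 nM, with a range from 3000 nM to 60000 nM, and the most likely outcome is that a limit is reported once more.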

Compound 4, half-maximal inhibitory concentration: > 10000 nM
Compound 4 gave a limit, no number (the forecaster's own chance of this, stated with the estimate: 75%); the middle value is on the limit's open side.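

In this assay compound 4 gives > 10000 nM, which is a limit of the assay and not a number. The step from compound 3 to compound 4 therefore cannot be read. The compounds shown leave open how far any of them lies past the limit and whether any change on the carbonyl carbon would give a measurable value, as the set still rests on one figure: the limit of > 10000 nM in this assay, at which 4 of the 4 values shown sit.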